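The source may report more compounds than this note shows. Statements on the series, on what has been measured and on what is new or still open speak of the compounds shown alone.

Compound 1, with the structure `COc1ccc(N(C)c2nc(C)nc3ccccc23)cc1C(=O)OCCCCC[Se]C#N`, and compound 2, with the structure `COc1ccc(N(C)c2nc(C)nc3ccccc23)cc1C(=O)OCC[Se]C#N`, share one core and differ only in the chain that carries the selenium-bearing end. In a functional assay on HepG2 cells (Homo sapiens) for inhibition, read by MTT assay, with a stated time of 48 h (a higher number here means a weaker inhibitor, a lower number a stronger inhibitor), compound 1 gives 667 nM, and compound 2 gives 890 nM. Of the two numbers measured, compound 2 has the larger, but the gap to compound 1 does not exceed the scatter: a 1.3-fold higher number from compound 1 to compound 2 (0.13 log units; within the scatter), so the two are best read as equal.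

Compound 3, with the structure `COc1ccc(N(C)c2nc(C)nc3ccccc23)cc1OCCCC[Se]C#N`, is not yet measured. Its change from compound 2 is a group of 8 heavy atoms (5 carbon, 1 nitrogen, 1 oxygen, 1 selenium; no ring) in place of a group of 8 heavy atoms (4 carbon, 1 nitrogen, 2 oxygen, 1 selenium; no ring), on an aromatic carbon. Going by the values given here, the only measured step, that from compound 1 to compound 2, shortened the chain on a saturated carbon and produced no shift beyond the scatter; no measured pair touches the replacement of a carbonyl-bearing chain by an oxygen-linked chain on the aromatic carbon. The expectation is therefore a step of about a 1.1-fold lower number from compound 2 to compound 3 (0.05 log units; within the scatter), that is, nothing beyond the scatter. Compound 3 is estimated at 800 nM in this assay, within a range from 300 nM to 2200 nM.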

Compound 3, half-maximal inhibitory concentration: 6460 nM
The estimate for compound 3 lay 8.1-fold (0.91 log units) below the measured number; measured number outside the range, above it.
By their numbers in this assay, from the lowest: compounds 1 and 2 (each within the scatter of the next); then compound 3.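

In this assay, going by these compounds alone, the change on this aromatic carbon, ortho to a methoxy group, gives a 7.3-fold higher number from compound 2 to compound 3 (0.86 log units; beyond the scatter) and is the first step to go beyond the scatter. The earlier step, a 1.3-fold higher number from compound 1 to compound 2 (0.13 log units; within the scatter), altered only the length of the chain and stayed within the scatter, whereas here both the group that leaves and the group that enters have 8 heavy atoms, so heavy-atom count alone does not set the number in this pair; the carbonyl-bearing chain and the oxygen-linked chain are not interchangeable at this position. No measurement available here explains why the number rises.

The step from compound 2 to compound 3 changes the link to the ring and the chain in one move, so the compounds shown cannot say which of the two accounts for the rise. Also open, going by these compounds, is how an amide link on this carbon would compare with the carbonyl-bearing chain, and whether a longer oxygen-linked chain would bring the number down again.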